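The source may hold more compounds than are shown below. What is called first, only, known or untested is meant among the compounds shown, and "the series" means these compounds.

Compound 1 `O=C(CCl)Nc1ccc(S(=O)(=O)Oc2ccccc2I)cc1`, compound 2 `CC(C)c1ccccc1OS(=O)(=O)c1ccc(NC(=O)CCCl)cc1` and compound 3 `O=C(CCCl)Nc1ccc(S(=O)(=O)Oc2ccccc2I)cc1` have been tested in a functional assay on HT-1080 cells (Homo sapiens) for antiproliferative activity, read by sulforhodamine B assay, with a stated time of 48 h; a lower number here means a stronger inhibitor, a higher number a weaker inhibitor. In this assay compound 1 gives 600 nM, compound 2 gives 6500 nM and compound 3 gives 4200 nM. The change chloromethyl in place of chloro on a saturated chain carbon bound to a carbonyl carbon produced a 7.0-fold higher number from compound 1 to compound 3 (0.85 log units; beyond the scatter). Between compound 2 and compound 3 the step is a 1.5-fold lower number from compound 2 to compound 3 (0.19 log units; within the scatter). The difference between the cores of compound 2 and compound 1 is not broken down here.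

Compound 4 `CC(C)c1ccccc1OS(=O)(=O)c1ccc(NC(=O)CCCCl)cc1` differs from compound 2 by chloromethyl in place of chloro on a saturated chain carbon, two bonds along the chain from a carbonyl carbon. The place is not the same: two bonds along the chain from a carbonyl carbon rather than bound to a carbonyl carbon, so this is the same kind of change, not the same. A weakening step is expected, a 1.8-fold higher number from compound 2 to compound 4 (0.27 log units; within the scatter), smaller than the earlier one because the earlier lengthening gave a 7.0-fold higher number from compound 1 to compound 3 (0.85 log units; beyond the scatter) from a stronger starting point. In this assay compound 4 is estimated at 12000 nM, expected between 4000 nM and 40000 nM.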

Compound 4, half-maximal inhibitory concentration: 3800 nM
The estimate for compound 4 lay 3.2-fold (0.50 log units) above the measured number; measured number outside the range, below it.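

On the core of compound 2, chloromethyl in place of chloro, two bonds along the chain from a carbonyl carbon, gives a 1.7-fold lower number from compound 2 to compound 4 (0.23 log units; within the scatter), which leaves this pair unseparated in this assay. The loss seen on the core of compound 1 does not carry over to this pair, and the two steps differ: the same change on two cores in this assay, a 7.0-fold higher number (0.85 log units; beyond the scatter) from compound 1 to compound 3 and a 1.7-fold lower number (0.23 log units; within the scatter) from compound 2 to compound 4, 12-fold (1.08 log units) apart, beyond the scatter of two such steps

The two steps also differ in place, bound to a carbonyl carbon in one and two bonds along the chain from a carbonyl carbon in the other, so the gap cannot be assigned to the core alone, and two pairs set no rule for other cores.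

The compounds shown leave open how either core responds to a longer chain still. Also open, going by these compounds, is whether an amine in place of chloro would keep the values seen here.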